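Extending a Methylamino Group: Expected Effect on Cytotoxicity

The source may report more compounds than this note shows. Statements on the series, on what has been measured and on what is new or still open speak of the compounds shown alone.

Compound 1 `CNc1nc(Nc2ccc(C#N)cc2)nc(Oc2cccc3ccccc23)n1`: 30300 nM in an ADME assay on MT4 cells (Homo sapiens) for cytotoxicity, read by MTT assay, with a stated time of 4 days; a lower number here means that less compound is tolerated, a higher number that more compound is tolerated
Compound 2 `CNc1nc(Nc2ccc(C#N)cc2)nc(Oc2ccc(Cl)c3ccccc23)n1`: 197000 nM

Compound 2 stands highest of the two numbers in this assay. Among the measured compounds shown here, the only measured step, a 6.5-fold higher number from compound 1 to compound 2 (0.81 log units; beyond the scatter), concerns chloro in place of hydrogen on an aromatic carbon. Compound 3 `CCCNc1nc(Nc2ccc(C#N)cc2)nc(Oc2ccc(Cl)c3ccccc23)n1` differs from compound 2 by ethyl in place of hydrogen on a saturated chain carbon bound to a nitrogen on an aromatic ring. For the measured compounds named here, no measured step touches a change of this kind, so nothing here argues for a shift in this assay beyond the scatter. Compound 3 is therefore expected to give 150000 nM, with a range from 50000 nM to 400000 nM. The expected step is a 1.3-fold lower number from compound 2 to compound 3 (0.12 log units; within the scatter).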

Compound 3, half-maximal cytotoxic concentration: 182000 nM
Compound 3: the middle estimate sits 1.2-fold (0.08 log units) below what was measured; the measured number falls inside the stated range.
By their numbers in this assay, from the lowest: compound 1; then compounds 3 and 2 (each within the scatter of the next).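

In this assay, replacing methylamino with propylamino gives a small change (a 1.1-fold lower number from compound 2 to compound 3 (0.03 log units; within the scatter)). Among the compounds shown here, this is the first look at this position, and on the chlorinated compounds ethyl in place of hydrogen here produces no shift that can be told from repeat measurements. Nothing measured here explains this result.

Still open, from the compounds shown here alone, is whether a longer chain, or an amine or carboxylic acid at the end of the chain, would leave the number just as unmoved. Also open, going by these compounds, is whether propylamino behaves the same way without the chloro group.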